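The compounds below may be only part of what the source reports. "The series", "measured", "known", "first", "only" and "open" are said of these compounds alone.

Measured in a functional assay on Bel7402/5-FU cells (Homo sapiens) for antiproliferative activity, read by MTT assay, with a stated time of 72 h; on this read-out higher numbers stand for weaker inhibition and lower numbers for stronger inhibition:
- compound 1 `C=C1C(=O)O[C@H]2[C@H]1CC/C(COC(=O)Cn1cc(F)c(=O)[nH]c1=O)=C\CC[C@@]1(C)O[C@@H]21`: > 20000 nM (a limit of the assay, not a number)
- compound 2 `C=C1C(=O)O[C@H]2[C@H]1CC/C(COC(=O)Cn1cc(F)c(=O)n(Cc3ccc(Br)cc3)c1=O)=C\CC[C@@]1(C)O[C@@H]21`: 3240 nM
- compound 3 `C=C1C(=O)O[C@H]2[C@H]1CC/C(COC(=O)Cn1cc(F)c(=O)n(Cc3ccc(C(F)(F)F)cc3)c1=O)=C\CC[C@@]1(C)O[C@@H]21`: 2250 nM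

Compound 3 shares the low end of these values with compound 2, and the step between them is small: a 1.4-fold lower number from compound 2 to compound 3 (0.16 log units; within the scatter). Compound 4 `C=C1C(=O)O[C@H]2[C@H]1CC/C(COC(=O)Cn1cc(F)c(=O)n(Cc3cccc(F)c3)c1=O)=C\CC[C@@]1(C)O[C@@H]21` differs from compound 3 at a single place: 3-fluorophenyl in place of 4-(trifluoromethyl)phenyl on a saturated chain carbon bound to an aromatic nitrogen. In words, 3-fluorophenyl stands in place of 4-(trifluoromethyl)phenyl on a saturated chain carbon bound to an aromatic nitrogen.

Two measured steps show what adding a substituted benzyl on the aromatic nitrogen did: an at least 6.1-fold lower number from compound 1 to compound 2 (0.79 log units; beyond the scatter) and an at least 8.8-fold lower number from compound 1 to compound 3 (0.94 log units; beyond the scatter). Compound 4 keeps a benzyl there and changes only its substituent. Among the measured compounds shown here, the one measured exchange of that kind, from compound 2 to compound 3, stayed within the scatter, though no measured compound carries the 3-fluorobenzyl group. In this assay, therefore, no step beyond the scatter is expected, with at most a slight drift to a higher number. The expected step is a 1.4-fold higher number from compound 3 to compound 4 (0.15 log units; within the scatter). Compound 4 is estimated at 3200 nM, with an expected range of 1400 nM to 9000 nM.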

Compound 4, half-maximal inhibitory concentration: 3700 nM
For compound 4 the middle estimate is 1.2-fold (0.06 log units) below the measured one; measured number inside the range.
By their numbers in this assay, from the lowest: compounds 3, 2 and 4 (each within the scatter of the next). At a limit, above all of these: compound 1.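

In this assay, replacing either 4-substituted benzyl with 3-fluorobenzyl gave no step beyond the scatter: a 1.6-fold higher number from compound 3 to compound 4 (0.22 log units; within the scatter), and a 1.1-fold higher number from compound 2 to compound 4 (0.06 log units; within the scatter). Across these three compounds, the benzyl on the aromatic nitrogen therefore tolerates a different substituent, with 3-fluorophenyl carrying fewer heavy atoms than 4-(trifluoromethyl)phenyl in the exchange from compound 3, and the difference from the parent also holds for this third benzyl, with an at least 5.4-fold lower number from compound 1 to compound 4 (0.73 log units; beyond the scatter). That step rests on a limit rather than a number for compound 1: the limit of > 20000 nM in this assay, at which 1 of the 4 values shown sits.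

As far as these compounds go, what an unsubstituted benzyl, a methyl or a longer alkyl chain on that nitrogen would give remains open. So does the effect of an amine or a carboxylic acid on the phenyl ring.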